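Swapping an ester for a fluorophenyl ring on the benzyl arm

This account rests on a few compounds, and the source may have more. Where it says the series, first, only, none or still open, it means among the compounds named here.

Measured compounds:
- compound 1 `Cc1c(Cc2ccc(C(C)(C)C)cc2)c(=O)oc2cc(OCC(O)CN3CCC(C(N)=O)CC3)ccc12`: 14700 nM
- compound 2 `Cc1c(Cc2ccc(F)cc2)c(=O)oc2cc(OCC(O)CN3CCC(C(N)=O)CC3)ccc12`: 89300 nM
- compound 3 `COC(=O)c1ccc(Cc2c(C)c3ccc(OCC(O)CN4CCC(C(N)=O)CC4)cc3oc2=O)cc1`: > 100000 nM

Three compounds share one core and differ only in the group on the benzyl ring. In an ADME assay on A549 cells (Homo sapiens) for cytotoxicity, read by CellTiter-Glo (on this read-out lower numbers stand for higher toxicity in this test and higher numbers for lower toxicity in this test), compound 1 gives 14700 nM. Compound 2 gives 89300 nM. For compound 3 the value > 100000 nM is a limit of the assay, not a number (the limit of > 100000 nM in this assay, at which 1 of the 3 values shown sits), so compound 3 stands at the top of the range shown, with the least toxicity measured.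

Compound 4 `Cc1c(Cc2ccc(-c3ccc(F)cc3)cc2)c(=O)oc2cc(OCC(O)CN3CCC(C(N)=O)CC3)ccc12` differs from compound 3 in one place: 4-fluorophenyl in place of methoxycarbonyl on an aromatic carbon.

Among the measured compounds shown here, two measured steps bear on this. From compound 1 to compound 3 the number rose an at least 6.8-fold higher number from compound 1 to compound 3 (0.83 log units; beyond the scatter), and from compound 1 to compound 2 it rose a 6.1-fold higher number from compound 1 to compound 2 (0.78 log units; beyond the scatter); the step of an at least 1.1-fold higher number from compound 2 to compound 3 (0.04 log units; that floor lies within the scatter) stays within the scatter. Removing the methoxycarbonyl that went with the highest number, and replacing it with a large aromatic group, is expected to move the number back downward, toward the value of compound 1, as the step of an at least 4.0-fold lower number from compound 3 to compound 4 (0.60 log units; beyond the scatter). Compound 4 is therefore estimated at 25000 nM, within 8000 nM to 100000 nM.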

Compound 4, half-maximal cytotoxic concentration: 19300 nM
Compound 4: middle estimate off by 1.3-fold (0.11 log units), on the high side, and the stated range covers the measured number.
By their numbers in this assay, from the lowest: compounds 1 and 4 (each within the scatter of the next); then compound 2. At a limit, above all of these: compound 3.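

Putting 4-fluorophenyl on this aromatic carbon in place of fluoro gives a 4.6-fold lower number from compound 2 to compound 4 (0.67 log units; beyond the scatter) in this assay, so adding an aromatic ring to the fluoro group goes with more toxicity in this test. Set against tert-butyl, the same group gives a 1.3-fold higher number from compound 1 to compound 4 (0.12 log units; within the scatter) and so cannot be told apart from it, which shows that tert-butyl is not the only group at this position that gives a number at the low end of this series. Replacing methoxycarbonyl gives an at least 5.1-fold lower number from compound 3 to compound 4 (0.71 log units; beyond the scatter) as a floor only, since compound 3 sits at a limit of the assay: the limit of > 100000 nM in this assay, at which 1 of the 4 values shown sits.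

A plain phenyl group would show whether the added ring alone goes with the lower number, or whether its fluorine plays a part. From the compounds shown here alone, it also remains open where an amine or a carboxylic acid on this aromatic carbon would fall.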